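Adding a Third Methoxy Group to an Aniline Chalcone

The compounds below may be only part of what the source reports. "The series", "measured", "known", "first", "only" and "open" are said of these compounds alone.

Three compounds have been measured in an ADME assay on CCRF-CEM cells (Homo sapiens) for antiproliferative activity, with a stated time of 48 h; a higher number here means a weaker inhibitor, a lower number a stronger inhibitor:

Compound 1 `C=C(Br)C(=O)Nc1ccc(/C=C/C(=O)c2ccccc2)cc1`: 4000 nM
Compound 2 `C=C(Br)C(=O)Nc1ccc(/C=C/C(=O)c2cccc(OC)c2)cc1`: 2300 nM
Compound 3 `COc1ccc(/C=C/C(=O)c2ccc(N)cc2)c(OC)c1`: 18000 nM

Compound 1 and compound 2 differ by methoxy in place of hydrogen on an aromatic carbon and the step between them, a 1.7-fold lower number from compound 1 to compound 2 (0.24 log units; within the scatter), is small. Compound 3 has another core; the difference between the two cores is not broken down here. Compound 4 `COc1ccc(/C=C/C(=O)c2ccc(N)cc2)c(OC)c1OC` is not yet measured and differs from compound 3 by methoxy in place of hydrogen on an aromatic carbon. Around the place, the entering methoxy in compound 4 sits ortho to two methoxy groups, which the earlier change did not, so this is the same kind of change, not the same. For compound 4 in this assay a small step is expected, a 1.5-fold lower number from compound 3 to compound 4 (0.18 log units; within the scatter), resting on the step of a 1.7-fold lower number from compound 1 to compound 2 (0.24 log units; within the scatter), which lay within the scatter. Compound 4 is therefore estimated at 12000 nM, expected between 5000 nM and 30000 nM.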

Compound 4, half-maximal inhibitory concentration: 9700 nM
Compound 4: middle estimate off by 1.2-fold (0.09 log units), on the high side; measured number inside the range.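

In this assay the added methoxy group gives a 1.9-fold lower number from compound 3 to compound 4 (0.27 log units; within the scatter) as its step, a small one, like the step on the core of compound 1. Set side by side, the two steps do not differ: the same change on two cores in this assay, a 1.7-fold lower number (0.24 log units; within the scatter) from compound 1 to compound 2 and a 1.9-fold lower number (0.27 log units; within the scatter) from compound 3 to compound 4, 1.1-fold (0.03 log units) apart, within the scatter of two such steps. So on these two cores the change moved the number by no more than repeated measurements would, even with the entering methoxy in compound 4 ortho to two methoxy groups, but this does not show that the change strengthens inhibition, and two cores do not make a rule for the whole series.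

The compounds shown leave open whether another group at this place, such as an amine, a carboxylic acid or a longer chain, would give a step beyond the scatter. They also leave open how the methoxy step would behave on a third core.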